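This account rests on a few compounds, and the source may have more. Where it says the series, first, only, none or still open, it means among the compounds named here.

Working notes on the series. Compound 1 `CCOC(=O)CC(CCCCCn1c(C)nc(-c2ccccc2)c1-c1ccccc1)C(C)C` is the weakest point in an assay on H4 cells for inhibition of Fatty-acid amide hydrolase 1 (Homo sapiens) (on this read-out lower numbers stand for stronger inhibition and higher numbers for weaker inhibition), shown so far. In this assay compound 1 gives only a limit, > 100000 nM, which is the limit of > 100000 nM in this assay, at which 1 of the 2 values shown sits. For the measured compounds named here, compound 2 `Cc1nc(-c2ccccc2)c(-c2ccccc2)n1CCCCCCC(=O)N(C)C` is the only compound with a number in this assay: compound 2 gives 970 nM. Going by the values given here, the single measured step is an at least 100-fold lower number from compound 1 to compound 2 (2.01 log units; beyond the scatter), a change that is far larger than the change now in question and sits at a different point of the chain. Compound 3 `CNC(=O)NCCCCCCn1c(C)nc(-c2ccccc2)c1-c1ccccc1` carries (methylcarbamoyl)amino in place of dimethylcarbamoyl on a saturated chain carbon, six bonds along the chain from an aromatic nitrogen. The chain length is kept, and the measured step does not involve the group that is exchanged here, so it gives no direct guide to direction. A modest step is expected, a 1.4-fold lower number from compound 2 to compound 3 (0.14 log units; within the scatter), most likely within the scatter. Compound 3 is estimated at 700 nM, with a range from 150 nM to 4000 nM.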

Compound 3, half-maximal inhibitory concentration: > 10000 nM
Compound 3: a limit, no number; the forecaster's own chance of this, stated with the estimate: 10%; middle value at least 14-fold (1.15 log units) away from the limit.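

In this assay, the exchange on a saturated chain carbon, six bonds along the chain from an aromatic nitrogen, is not tolerated as a like-for-like swap: the result is an at least 10-fold higher number from compound 2 to compound 3 (1.01 log units; beyond the scatter). For the compounds shown here, this is the first reading on the dimethylcarbamoyl group itself, and it shows that activity at this position depends on more than the size of the group, as the two groups match in heavy atoms. The value of compound 3 is a limit and not a number, and the step from compound 1 to compound 3 cannot be read, as both values are limits: the limit of > 10000 nM in this assay, at which 1 of the 3 values shown sits.

From the compounds shown here alone, the true size of the step therefore remains open. Also open, going by these compounds, is whether a (dimethylcarbamoyl)amino group, a primary amide or a carboxylic acid in the same place would give a measurable number.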